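Benzyl for methyl: a repeat of one structural step

This account rests on a few compounds, and the source may have more. Where it says the series, first, only, none or still open, it means among the compounds named here.

Compound 1 `Cn1c(SCC(=O)Nn2c(COc3ccc(Cl)cc3Cl)nc3ccccc3c2=O)nc(-c2ccc(Cl)cc2)c(C#N)c1=O` gives 80.8%. Compound 2 `N#Cc1c(-c2ccc(Cl)cc2)nc(SCC(=O)Nn2c(COc3ccc(Cl)cc3Cl)nc3ccccc3c2=O)n(Cc2ccccc2)c1=O` gives 61.5%. Compound 3 `Cn1c(SCC(=O)Nn2c(COc3ccc(Cl)cc3Cl)nc3ccccc3c2=O)nc(-c2ccc(O)cc2)c(C#N)c1=O` gives 76.9%.

These three were measured in a functional assay on the whole organism (strain albino) for inhibition, with Rattus norvegicus as the target, read by paw edema, with stated times of 1 h and 0.5 h, at a dose of 100 mg/kg by the oral route; a higher number here means more inhibition at the dose given (going by the name of the read-out), a lower number less inhibition. The change from compound 1 to compound 2 is phenyl in place of hydrogen on a saturated chain carbon bound to an aromatic nitrogen, and it produced a number 19.3 percentage points lower from compound 1 to compound 2 (beyond the scatter). Compound 3 differs from compound 1 by hydroxy in place of chloro on an aromatic carbon, and that gave a number 3.9 percentage points lower from compound 1 to compound 3 (within the scatter), so compound 1 and compound 3 cannot be set in order.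

Compound 4 `N#Cc1c(-c2ccc(O)cc2)nc(SCC(=O)Nn2c(COc3ccc(Cl)cc3Cl)nc3ccccc3c2=O)n(Cc2ccccc2)c1=O` has not been measured. It differs from compound 3 by phenyl in place of hydrogen on a saturated chain carbon bound to an aromatic nitrogen, the same kind of change as that from compound 1 to compound 2, made on a core that carries hydroxy rather than chloro. The expectation for compound 4 rests on one pair only: since the step from compound 1 to compound 2 was a number 19.3 percentage points lower from compound 1 to compound 2 (beyond the scatter), a step of similar size is expected, namely a number 18.9 percentage points lower from compound 3 to compound 4 (beyond the scatter). Going by the values given here, with only one earlier example, the width of the expected range is kept generous. Compound 4 is therefore estimated at 58%, between 45% and 70%.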

Compound 4, a percentage reported as inhibition, in the whole organism at one dose (the size of the read-out at that dose, not a potency): 51.9%
Estimate against measurement, compound 4: 6.1 percentage points above; measured number inside the range.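

Putting benzyl in place of methyl on the core that carries hydroxy gave a number 25 percentage points lower from compound 3 to compound 4 (beyond the scatter), and this drop in this assay matches the one seen on the core that carries chloro: the same change on two cores in this assay, a number 19.3 percentage points lower (beyond the scatter) from compound 1 to compound 2 and a number 25 percentage points lower (beyond the scatter) from compound 3 to compound 4, 5.7 percentage points apart, within the scatter of two such steps. Hydroxy in place of chloro, read on the benzyl compounds, gave a number 9.6 percentage points lower from compound 2 to compound 4 (within the scatter), so that change also carried over without a detectable difference: the same change on two cores in this assay, a number 3.9 percentage points lower (within the scatter) from compound 1 to compound 3 and a number 9.6 percentage points lower (within the scatter) from compound 2 to compound 4, 5.7 percentage points apart, within the scatter of two such steps. This shows that, across these four compounds, each change had much the same effect on both cores, but it rests on just two pairs per change at a single dose, so it neither establishes that the steps would hold on other cores nor explains why benzyl lowers the number.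

The compounds shown leave open how an ethyl group or a longer chain would behave in place of the methyl or benzyl. They also leave open whether a methoxy group or an amine in place of the hydroxy would fit the same pattern.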